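Bromo removal and benzyl extension against HEK-293T cytotoxicity

The compounds below may be only part of what the source reports. "The series", "measured", "known", "first", "only" and "open" are said of these compounds alone.

Measured compounds:
compound 1 `CN(Cc1ccccc1)C(=O)CSc1c[nH]c2c(Br)cccc12` — 52500 nM
compound 2 `CN(Cc1ccccc1)C(=O)CSc1c[nH]c2ccccc12` — > 100000 nM

In an ADME assay on HEK-293T cells (Homo sapiens) for cytotoxicity, read by CCK-8 assay, with a stated time of 24 h (on this read-out lower numbers stand for higher toxicity in this test and higher numbers for lower toxicity in this test), compound 1 gives 52500 nM. Compound 2 stands at the ceiling of this assay, > 100000 nM, which is a limit and not a number. On these data alone, the step of an at least 1.9-fold higher number from compound 1 to compound 2 (0.27 log units; that floor lies within the scatter) runs into (the limit of > 100000 nM in this assay, at which 1 of the 2 values shown sits), so its true size is unknown. Compound 3 `O=C(CSc1c[nH]c2ccccc12)N(Cc1ccccc1)Cc1ccccc1` differs from compound 2 by phenyl in place of hydrogen on a saturated chain carbon bound to an amide-type nitrogen. No measured step touches this change, and the one step shown concerns a different position. With compound 2 already at the limit, compound 3 is expected to stay there too, a step that the limit leaves unreadable from compound 2 to compound 3 giving an estimate of 120000 nM within 50000 nM to 300000 nM.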

Compound 3, half-maximal cytotoxic concentration: > 100000 nM
Compound 3: a limit, no number; the forecaster's own chance of this, stated with the estimate: 65%; the middle value lies beyond the limit too.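

Compound 3 gives > 100000 nM in this assay, which is a limit and not a number. No step between compound 2 and compound 3 can be read, because both stand at that limit: the limit of > 100000 nM in this assay, at which 2 of the 3 values shown sit.

The compounds shown leave open whether methyl to benzyl changes the true value at all.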